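The compounds below may be only part of what the source reports. "The series", "measured", "known", "first", "only" and "open" are said of these compounds alone.

Measured in a functional assay on A549 cells (Homo sapiens) for antiproliferative activity, with a stated time of 5 days (a lower number here means a stronger inhibitor, a higher number a weaker inhibitor), so far:
- compound 1 `O=C1C=CC2(C=C1)OCC(=O)N2c1nc(-c2ccc3c(c2)OCCO3)nn1-c1ccccc1` at 170 nM
- compound 2 `O=C1C=CC2(C=C1)OCC(=O)N2c1nc(-c2ccc(F)c3ccccc23)nn1-c1ccccc1` at 320 nM
- compound 3 `O=C1C=CC2(C=C1)OCC(=O)N2c1nc(-c2ccc3ccccc3c2)nn1-c1ccc(Cl)cc1` at 400 nM

Compound 3 lies within the scatter of compound 2 and beyond the scatter from compound 1, whose number is lower.

Next in line is compound 4 `O=C1C=CC2(C=C1)OCC(=O)N2c1nc(-c2ccc3ccccc3c2)nn1-c1ccccc1`, not yet measured. The change from compound 3 (hydrogen in place of chloro on an aromatic carbon) is hydrogen in place of chloro on an aromatic carbon, para to a large group, so 4-chlorophenyl becomes phenyl.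

For the measured compounds named here, no measured step covers this change. Going by the values given here, the one step available (a 1.9-fold higher number from compound 1 to compound 2 (0.27 log units; within the scatter)) concerns a different place and lies within the scatter, so it offers only indirect guidance. It gives no direction for the loss of chloro. A small change is therefore expected: the estimated step (a 1.3-fold lower number from compound 3 to compound 4 (0.10 log units; within the scatter)) stays within the scatter, and no firm direction is expected.

For compound 4 the expected value in this assay is 320 nM (estimated range 130 nM to 750 nM).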

Compound 4, half-maximal inhibitory concentration: 140 nM
Estimate against measurement, compound 4: 2.3-fold (0.36 log units) above; measured number inside the range.
By their numbers in this assay, from the lowest: compounds 4, 1, 2 and 3 (each within the scatter of the next, the first and the last beyond it).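

In this assay, for the compounds shown here, the change from 4-chlorophenyl to phenyl, with naphthalen-2-yl held constant, gives a 2.9-fold lower number from compound 3 to compound 4 (0.46 log units; beyond the scatter) as the first measured step at this position, so the chloro is not neutral in this pair. With phenyl held constant, naphthalen-2-yl in place of 4-fluoronaphthalen-1-yl gives a 2.3-fold lower number from compound 2 to compound 4 (0.36 log units; beyond the scatter) and separates those two groups, whereas a 1.2-fold lower number from compound 1 to compound 4 (0.08 log units; within the scatter) does not separate naphthalen-2-yl from 2,3-dihydro-1,4-benzodioxin-6-yl. No supporting data bear on the cause of these steps.

Only chloro and hydrogen are shown on this ring, so a methoxy group or an amine in the same place remains open. Also open, on these data alone, is whether the chloro step carries over when 2,3-dihydro-1,4-benzodioxin-6-yl replaces naphthalen-2-yl.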